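Shrinking the ring-nitrogen substituent: compound 4 expected

The compounds below may be only part of what the source reports. "The series", "measured", "known", "first", "only" and "open" are said of these compounds alone.

Compound 1 `CCN(CC)c1ccc2cc(C(=O)c3ccc(N4CCN(C(=O)CN5CCNCC5)CC4)cc3)oc2c1` gives 1220 nM in a functional assay on SGC-7901 cells (Homo sapiens) for cytotoxicity, read by MTT assay, with a stated time of 48 h; a higher number here means a weaker inhibitor, a lower number a stronger inhibitor. Compound 2 `CCN(CC)c1ccc2cc(C(=O)c3ccc(N4CCN(C(=O)CN5CCN(S(=O)(=O)c6ccc(OC(F)(F)F)cc6)CC5)CC4)cc3)oc2c1` gives 24400 nM in this assay. For compound 3 `CCN(CC)c1ccc2cc(C(=O)c3ccc(N4CCN(C(=O)CN5CCN(S(=O)(=O)c6ccc(F)cc6)CC5)CC4)cc3)oc2c1` only a limit of this assay is known, > 40000 nM, so compound 3 stands at the floor of the numbers shown (the limit of > 40000 nM in this assay, at which 1 of the 3 values shown sits). The step of an at least 32-fold higher number from compound 1 to compound 3 (1.51 log units; beyond the scatter) is large, whereas the step of an at least 1.6-fold higher number from compound 2 to compound 3 (0.21 log units; that floor lies within the scatter) lies within the scatter. Compound 4 `CCN(CC)c1ccc2cc(C(=O)c3ccc(N4CCN(C(=O)CN5CCN(CC(C)=O)CC5)CC4)cc3)oc2c1` differs from compound 3 by 2-oxopropyl in place of (4-fluorophenyl)sulfonyl on an amine nitrogen in a ring. The step from compound 1 to compound 3 bears on this change: placing (4-fluorophenyl)sulfonyl on the ring nitrogen raised the number steeply, so returning to a smaller 2-oxopropyl group is expected to lower it again, with an at least 11-fold lower number from compound 3 to compound 4 (1.05 log units; beyond the scatter) expected as a large downward step. Compound 4 is thus estimated at 3500 nM, in the range 1000 nM to 15000 nM.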

Compound 4, half-maximal inhibitory concentration: 2210 nM
For compound 4 the middle estimate is 1.6-fold (0.20 log units) above the measured one; low and high end bracket the measured number.
By their numbers in this assay, from the lowest: compounds 1 and 4 (each within the scatter of the next); then compound 2. At a limit, above all of these: compound 3.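

Putting 2-oxopropyl in place of (4-fluorophenyl)sulfonyl on this ring nitrogen gives an at least 18-fold lower number from compound 3 to compound 4 (1.25 log units; beyond the scatter) in this assay. Compound 3 stands only as a limit: the limit of > 40000 nM in this assay, at which 1 of the 4 values shown sits. Against the free ring nitrogen, the same group gives a 1.8-fold higher number from compound 1 to compound 4 (0.26 log units; within the scatter), so substitution here does not by itself raise the number, although the (4-fluorophenyl)sulfonyl of compound 3 does.

Open, going by these compounds, is whether the sulfonyl link or the aromatic ring carries the large step, which a methanesulfonyl or benzyl group on this nitrogen would separate. Also open, on these data alone, is how a longer chain ending in a ketone would read.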